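Compound 3: methoxy in place of methyl

A few compounds are considered here, and "the series" means these few. Any claim that something is new, unique, unknown or untested is made for them only; others in the source may bear on it.

In a functional assay on Huh-7 cells (Homo sapiens) for cytotoxicity, read by MTT assay, with a stated time of 72 h (a lower number here means that less compound is tolerated, a higher number that more compound is tolerated), compound 1 (`O=S(=O)(Cc1ccccc1)N1CCC2(CC1)OOC1(CCCCC1)OO2`) gives > 100 ug/mL and this is a limit of the assay, not a number. Compound 2 (`Cc1ccc(S(=O)(=O)N2CCC3(CC2)OOC2(CCCCC2)OO3)cc1`) gives > 100 ug/mL in this assay and this too is only a limit, so compound 2 has no number of its own.

The next change leads to compound 3 (`COc1ccc(S(=O)(=O)N2CCC3(CC2)OOC2(CCCCC2)OO3)cc1`), with methoxy in place of methyl on an aromatic carbon. For the measured compounds named here, the one measured step is a step that the two limits leave unreadable from compound 1 to compound 2 and it offers no size to carry over. The evidence stops at the limit of > 100 ug/mL in this assay, at which 2 of the 2 values shown sit, for now. Since compound 2 stands at the limit of > 100 ug/mL no step beyond the scatter is expected in this assay and no direction can be given. The estimated step is a number no higher from compound 2 to compound 3 (the limit leaves the size open) on that reading. Compound 3 is expected at 100 ug/mL with an estimated range from 50 ug/mL to 200 ug/mL and another report as a limit is the likely outcome.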

Compound 3, half-maximal cytotoxic concentration: > 100 ug/mL
Compound 3: only a limit was reported; the forecaster's own chance of this, stated with the estimate: 80%; the middle value lies on the limit itself.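

No step can be read among compound 1, compound 2 and compound 3, because each result is only a limit of the assay: the limit of > 100 ug/mL in this assay, at which 3 of the 3 values shown sit.

The compounds shown leave open at what concentration any of them becomes cytotoxic, and whether methoxy in place of methyl changes that concentration.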